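Compound 3 to compound 4: one aryl group exchanged

This account rests on a few compounds, and the source may have more. Where it says the series, first, only, none or still open, it means among the compounds named here.

In a physicochemical assay for lipophilicity, read by HPLC, at pH 7.5 (on this read-out lower numbers stand for lower lipophilicity and higher numbers for higher lipophilicity), compound 1 `CC[C@@H](Nc1c(C#N)c(-c2ccc(-c3ccccc3F)cc2)nc2cnccc12)C(N)=O` gives 2.7, compound 2 `CC[C@@H](Nc1c(C#N)c(-c2ccc(-c3cccc(Cl)c3F)cc2)nc2cnccc12)C(N)=O` gives 3.1 and compound 3 `CC[C@@H](Nc1c(C#N)c(-c2ccc(-c3cccc(Cl)c3OC)cc2)nc2cnccc12)C(N)=O` gives 3.1, so compound 3 stands level with compound 2 at the top of the three. Compound 4 `CC[C@@H](Nc1c(C#N)c(-c2ccc(-c3cccc(CO)c3)cc2)nc2cnccc12)C(N)=O` carries 3-(hydroxymethyl)phenyl in place of 3-chloro-2-methoxyphenyl on an aromatic carbon. Chloro in place of hydrogen came with a number 0.40 log units higher from compound 1 to compound 2 (beyond the scatter). The exchange of 2-fluorophenyl for 3-chloro-2-methoxyphenyl came with a number 0.40 log units higher from compound 1 to compound 3 (beyond the scatter), and methoxy in place of fluoro with no change at the digits printed from compound 2 to compound 3 (within the scatter). Going by the values given here, compound 4 has no chloro, and no measured step covers hydroxymethyl, so the size is uncertain. The expected change is a lower number beyond the scatter, a number 0.90 log units lower from compound 3 to compound 4 (beyond the scatter). Compound 4 is estimated at 2.2, within 1.8 to 2.6.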

Compound 4, distribution coefficient: 2
Compound 4: middle estimate off by 0.20 log units, on the high side, and the stated range covers the measured number.
By their numbers in this assay, from the lowest: compound 4; then compound 1; then compounds 2 and 3 (each within the scatter of the next).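

At this place, para to a large group, 3-(hydroxymethyl)phenyl gives the first downward steps shown in this assay: a number 1.10 log units lower from compound 3 to compound 4 (beyond the scatter) and a number 1.10 log units lower from compound 2 to compound 4 (beyond the scatter). The number also falls against 2-fluorophenyl, a number 0.70 log units lower from compound 1 to compound 4 (beyond the scatter), so compound 4 lies beyond the scatter below all three earlier compounds. No supporting data account for these steps.

Going by these compounds, each exchange alters more than one feature of the aryl group, so the share of hydroxymethyl itself stays open. Also open, on these data alone, is how an aminomethyl or carboxylic acid group would read at this place.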